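The source may report more compounds than this note shows. Statements on the series, on what has been measured and on what is new or still open speak of the compounds shown alone.

Of the compounds shown here, three sharing one core have been tested, and a fourth awaits its result. Compound 1, `COc1c(-c2ccc(C(C)C)cc2)oc2ccc(C(=O)O)cc2c1=O`, gives 18% in a functional assay on the whole organism (stomach) for inhibition, with Rattus norvegicus as the target, at a dose of 80 mg/kg; on this read-out higher numbers stand for more inhibition at the one dose given (going by the name of the read-out) and lower numbers for less inhibition. Compound 2, `COc1ccc(-c2oc3ccc(C(=O)O)cc3c(=O)c2OC)cc1`, gives 22% in this assay. Compound 3, `CC(C)Oc1c(-c2ccc(C(C)C)cc2)oc2ccc(C(=O)O)cc2c1=O`, gives 20% in this assay. Among the compounds with values here, the three numbers sit close together, and none of the measured pairs is separated by more than the usual scatter of this kind of measurement.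

Two single changes link the measured compounds. The first, (methoxy in place of isopropyl on an aromatic carbon), produced a number 4 percentage points higher from compound 1 to compound 2 (within the scatter). The second, (isopropyl in place of methyl on an oxygen on an aromatic ring), produced a number 2 percentage points higher from compound 1 to compound 3 (within the scatter); this is also how the core of compound 1 differs from the core of compound 3.

Compound 4, `COc1ccc(-c2oc3ccc(C(=O)O)cc3c(=O)c2OC(C)C)cc1`, has not yet been measured. It differs from compound 3 by methoxy in place of isopropyl on an aromatic carbon. This is the same change already made from compound 1 to compound 2, carried out on the other core, and it appears twice among the four compounds. Since the earlier instance of this change stayed within the scatter, and since compound 3 itself gives 20%, compound 4 is expected to land near its parent: the expected step is a number 3 percentage points higher from compound 3 to compound 4 (within the scatter), beside the earlier a number 4 percentage points higher from compound 1 to compound 2 (within the scatter). Compound 4 is therefore estimated at 23% in this assay, most likely between 12% and 34%, with the result to be read against that expectation.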

Compound 4, a percentage reported as inhibition, in the whole organism at one dose (the size of the read-out at that dose, not a potency): 35%
Beside the measured number, compound 4's estimate is 12 percentage points below it; the whole stated range lies below it.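

On the core that carries the isopropyl group on the oxygen, replacing 4-isopropylphenyl with 4-methoxyphenyl gave a number 15 percentage points higher from compound 3 to compound 4 (beyond the scatter) in this assay, and on the core with the 4-methoxyphenyl group, isopropyl in place of methyl on the oxygen gave a number 13 percentage points higher from compound 2 to compound 4 (beyond the scatter). Although the new step for the phenyl change lies beyond the scatter and the earlier one within it, the two cannot be told apart, so carrying this change to the other core is not shown to alter its size: the same change on two cores in this assay, a number 4 percentage points higher (within the scatter) from compound 1 to compound 2 and a number 15 percentage points higher (beyond the scatter) from compound 3 to compound 4, 11 percentage points apart, within the scatter of two such steps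

The change on the oxygen reads the same way, and with only one pair of steps for each change, the series neither establishes that the effect of either change depends on the core nor proves that it does not: the same change on two cores in this assay, a number 2 percentage points higher (within the scatter) from compound 1 to compound 3 and a number 13 percentage points higher (beyond the scatter) from compound 2 to compound 4, 11 percentage points apart, within the scatter of two such steps

The compounds shown carry only isopropyl or methoxy on the phenyl ring and only methyl or isopropyl on the oxygen, so it remains open how a chloro group or an amine on that ring, or a longer chain on the oxygen, would read in this assay. All four also keep the carboxylic acid, which leaves open what an amide or an ester in its place would do.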